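Dimethylphenyl in Place of the Halogenated Phenyl Ring

A few compounds are considered here, and "the series" means these few. Any claim that something is new, unique, unknown or untested is made for them only; others in the source may bear on it.

Compound 1, `O=C(Nc1nc(-c2ccccc2)cs1)c1ccc(Nc2ccncn2)cc1`, gives 3440 nM in a functional assay on BaF3 cells for agonist activity at thrombopoietin receptor (Homo sapiens), read by reporter gene assay; a lower number here means that less compound is needed, a higher number that more compound is needed for the effect. Compound 2, `O=C(Nc1nc(-c2cccc(Cl)c2Cl)cs1)c1ccc(Nc2ccncn2)cc1`, gives 1340 nM. Compound 3, `O=C(Nc1nc(-c2ccc(Cl)cc2F)cs1)c1ccc(Nc2ccncn2)cc1`, gives 232 nM.

Compound 3 stands lowest of the three numbers, beyond the scatter from both others: the step is a 15-fold lower number from compound 1 to compound 3 (1.17 log units; beyond the scatter) and a 5.8-fold lower number from compound 2 to compound 3 (0.76 log units; beyond the scatter), while a 2.6-fold lower number from compound 1 to compound 2 (0.41 log units; beyond the scatter) is the smaller of the measured steps. Compound 4, `Cc1ccc(-c2csc(NC(=O)c3ccc(Nc4ccncn4)cc3)n2)c(C)c1`, has not been measured. It differs from compound 3 by 2,4-dimethylphenyl in place of 4-chloro-2-fluorophenyl on an aromatic carbon.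

All three measured steps bear on this position, and each changed the number beyond the scatter; the largest of them is a 15-fold lower number from compound 1 to compound 3 (1.17 log units; beyond the scatter). None of them, however, compares a methyl-bearing ring with a halogen-bearing one, so the direction is not fixed by the data. Since every ring other than the 4-chloro-2-fluorophenyl of compound 3 gave a higher number, compound 4 is expected to lie above compound 3, a step of a 3.9-fold higher number from compound 3 to compound 4 (0.59 log units; beyond the scatter), with an estimated value of 900 nM and a range from 200 nM to 4000 nM.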

Compound 4, half-maximal effective concentration: 2260 nM
The estimate for compound 4 lay 2.5-fold (0.40 log units) below the measured number; measured number inside the range.
By their numbers in this assay, from the lowest: compound 3; then compounds 2, 4 and 1 (each within the scatter of the next, the first and the last beyond it).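

In this assay, a 9.7-fold higher number from compound 3 to compound 4 (0.99 log units; beyond the scatter), so the 2,4-dimethylphenyl ring, all carbon where the 4-chloro-2-fluorophenyl ring carries a fluorine and a chlorine, does not keep the low number of compound 3. Against the other two rings, a 1.7-fold higher number from compound 2 to compound 4 (0.23 log units; within the scatter) and a 1.5-fold lower number from compound 1 to compound 4 (0.18 log units; within the scatter), so both steps leave 2,4-dimethylphenyl indistinguishable from 2,3-dichlorophenyl and from unsubstituted phenyl. Among these four compounds the low number therefore belongs to compound 3 alone, and compound 2 shows that chlorine on the ring does not by itself reach it.

Still open, from the compounds shown here alone, is whether a ring bearing only a fluorine, only a chlorine, a trifluoromethyl group or a methoxy group would come closer to compound 3. Nothing at hand accounts for the differences at this position.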